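Oxan-4-yl for Isopropyl: Expected Tissue Distribution of Compound 3

The source may hold more compounds than are shown below. What is called first, only, known or untested is meant among the compounds shown, and "the series" means these compounds.

Measured compounds:
compound 1 `COC(=O)N1CCN([C@H]2CC[C@H](Nc3ncnn4ccc([C@H](C)CC(N)=O)c34)CC2)CC1` — 1.9 L/kg
compound 2 `CC(=O)N1CCN([C@H]2CC[C@H](Nc3ncnn4ccc(C(C)C)c34)CC2)CC1` — 2.2 L/kg

Of the compounds shown here, two built on the shared core have been tested in an ADME assay on the whole organism (strain Han Wistar) for pharmacokinetics, with Rattus norvegicus as the target; on this read-out lower numbers stand for narrower distribution and higher numbers for wider distribution into tissues. In this assay compound 1 gives 1.9 L/kg, and compound 2 gives 2.2 L/kg. The two numbers lie within the usual scatter of each other, so on this read-out compound 1 and compound 2 cannot be told apart, even though they differ in more than one place.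

Compound 3 `CC(=O)N1CCN([C@H]2CC[C@H](Nc3ncnn4ccc(C5CCOCC5)c34)CC2)CC1` is the next compound to be measured. It differs from compound 2 at a single place: oxan-4-yl in place of isopropyl on an aromatic carbon. The oxan-4-yl group brings a six-membered non-aromatic ring with one oxygen, and with it one hydrogen-bond acceptor, where the isopropyl group had none.

Among the compounds with values here, no measured pair here shows this exact exchange, so the expectation rests on how steady the two measured numbers have been. Compound 3 is therefore expected to give about 1.8 L/kg, with a range from 1 L/kg to 3.2 L/kg. That estimate means a step of a 1.2-fold lower number from compound 2 to compound 3 (0.09 log units; within the scatter), expected to stay within the scatter rather than move the number in either direction.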

Compound 3, volume of distribution at steady state: 2.4 L/kg
Compound 3: the middle estimate sits 1.3-fold (0.12 log units) below what was measured; the measured number falls inside the stated range.
By their numbers in this assay, from the lowest: compounds 1, 2 and 3 (each within the scatter of the next).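

In this assay, within the data shown here, placing oxan-4-yl instead of isopropyl on this aromatic carbon gives a 1.1-fold higher number from compound 2 to compound 3 (0.04 log units; within the scatter), so this one pair offers the first direct look at this position, and the two compounds cannot be told apart on this read-out. At this site, two ring bonds from the ring nitrogen, a six-membered non-aromatic ring with one oxygen and a hydrogen-bond acceptor can thus stand where a smaller, ring-free group stood, without a step beyond the scatter. Nothing available explains why the number holds steady across this exchange.

The compounds shown leave open whether the position would remain as undemanding with a group of a different kind, such as an amine, a carboxylic acid or a longer chain. A single pair also cannot show whether the same exchange would give a similar result on a compound that differs elsewhere on the shared core, so this finding applies only to compound 2 and compound 3.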